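Replacing Methyl with a Quinolinyl Group on a Shared Core

This account rests on a few compounds, and the source may have more. Where it says the series, first, only, none or still open, it means among the compounds named here.

The measured compounds are:
compound 1, `Cc1nc2c3ccccc3ccc2c2nc3c(ccc4ccccc43)c(-c3ccccc3S)c12`, with 49.6 ug/mL in a functional assay, read by spectrophotometry, with a stated time of 15 min; on this read-out higher numbers stand for weaker inhibition and lower numbers for stronger inhibition;
compound 2, `Cc1nc2c3ccccc3ccc2c2nc3c(ccc4ccccc43)c(-c3cc([N+](=O)[O-])ccc3N)c12`, with 43.3 ug/mL;
compound 3, `Cc1nc2c3ccccc3ccc2c2nc3c(ccc4ccccc43)c(C)c12`, with 89.6 ug/mL.

Compound 3 gives the highest of the three numbers: the step of a 1.8-fold higher number from compound 1 to compound 3 (0.26 log units; within the scatter) stays within the scatter, while the step of a 2.1-fold higher number from compound 2 to compound 3 (0.32 log units; beyond the scatter) is a modest one beyond it. Compound 4, `Cc1nc2c3ccccc3ccc2c2nc3c(ccc4ccccc43)c(-c3cc(O)nc4ccccc34)c12`, differs from compound 3 in one place: 2-hydroxyquinolin-4-yl in place of methyl on an aromatic carbon. Both measured steps that bear on this change run from an aryl group to methyl and both gave higher numbers, so the reverse direction is expected to give a modestly lower number, a 2.0-fold lower number from compound 3 to compound 4 (0.30 log units; within the scatter). Compound 4 is therefore estimated at 45 ug/mL, with a range from 25 ug/mL to 80 ug/mL.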

Compound 4, half-maximal inhibitory concentration: 44.8 ug/mL
Compound 4: the middle estimate sits 1.0-fold (0.00 log units) above what was measured; the measured number falls inside the stated range.
By their numbers in this assay, from the lowest: compounds 2, 4, 1 and 3 (each within the scatter of the next, the first and the last beyond it).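

In this assay, a two-ring group with a hydroxyl at this aromatic carbon gives a 2.0-fold lower number from compound 3 to compound 4 (0.30 log units; within the scatter) and so cannot be separated from methyl. The same group also stays level with the two single-ring aryl groups, with a 1.0-fold higher number from compound 2 to compound 4 (0.01 log units; within the scatter) and a 1.1-fold lower number from compound 1 to compound 4 (0.04 log units; within the scatter) showing that the added ring does not set it apart from them. No evidence is available to account for these readings. From the compounds shown here alone, it remains open how an amine or a carboxylic acid at this carbon would read, and whether the hydroxyl on the quinoline matters.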